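The source may report more compounds than this note shows. Statements on the series, on what has been measured and on what is new or still open speak of the compounds shown alone.

Compound 1 `Cc1cc(Nc2cc(-c3ccccc3)[nH]n2)n2nc(SCc3c(Cl)cccc3Cl)nc2n1` stands second highest of the three numbers in a functional assay on MGC-803 cells (Homo sapiens) for inhibition, read by MTT assay, with a stated time of 72 h (a higher number here means a weaker inhibitor, a lower number a stronger inhibitor), where compound 1 gives 5280 nM. Compound 3 `Cc1cc(Nc2cc(-c3ccc(Cl)cc3)[nH]n2)n2nc(SCc3ccc(Br)cc3)nc2n1` gives 2780 nM in this assay, a value lying within the scatter of that of compound 1. Within the data shown here, compound 2 `C#CCSc1nc2nc(C)cc(Nc3cc(-c4ccccc4)[nH]n3)n2n1` gives 13400 nM in this assay, and the step of a 2.5-fold higher number from compound 1 to compound 2 (0.40 log units; beyond the scatter) is the only measured change at the same place. Compound 4 `CCCSc1nc2nc(C)cc(Nc3cc(-c4ccccc4)[nH]n3)n2n1` has not yet been measured; it differs from compound 1 by ethyl in place of 2,6-dichlorophenyl on a saturated chain carbon bound to a sulfur. The change bears a clear resemblance to the measured one, because a 2.5-fold higher number from compound 1 to compound 2 (0.40 log units; beyond the scatter) also took away the 2,6-dichlorophenyl from the saturated chain carbon bound to a sulfur and left a small group in its place, so a step of similar kind and size toward a higher number is expected for compound 4, a 2.1-fold higher number from compound 1 to compound 4 (0.32 log units; beyond the scatter). Compound 4 is therefore estimated at 11000 nM in this assay, with a range from 4500 nM to 28000 nM.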

Compound 4, half-maximal inhibitory concentration: 12600 nM
Beside the measured number, compound 4's estimate is 1.1-fold (0.06 log units) below it; low and high end bracket the measured number.
By their numbers in this assay, from the lowest: compounds 3 and 1 (each within the scatter of the next); then compounds 4 and 2 (each within the scatter of the next).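

In this assay ethyl in place of 2,6-dichlorophenyl on a saturated chain carbon bound to a sulfur gives a 2.4-fold higher number from compound 1 to compound 4 (0.38 log units; beyond the scatter) and so shows that the step seen with ethynyl is not confined to that one small group. The two small groups cannot be told apart, with a 1.1-fold lower number from compound 2 to compound 4 (0.03 log units; within the scatter) at this place, so in these compounds the step follows the loss of 2,6-dichlorophenyl and not the identity of the group that enters. Nothing measured here offers an explanation for these steps.

The compounds shown leave open whether the ring of 2,6-dichlorophenyl or its two chlorines separate compound 1 from compound 2 and compound 4, a question that a plain phenyl at this place would address. Going by these compounds, how a longer chain such as hexyl, or an amine, would read here is also open.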